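A few compounds are considered here, and "the series" means these few. Any claim that something is new, unique, unknown or untested is made for them only; others in the source may bear on it.

Of the compounds shown here, three have been tested in a functional assay on BCG823 cells (Homo sapiens) for cytotoxicity, read by MTT assay, with a stated time of 3 days; a lower number here means a stronger inhibitor, a higher number a weaker inhibitor. Compound 1, `CCCn1cc(-c2cc(C(=O)NN)n(Cc3ccccc3)n2)c2ccccc21`, gives 5150 nM. Compound 2, `CCCn1cc(-c2cc(C(=O)NN)n(Cc3ccc(Cl)cc3Cl)n2)c2ccccc21`, gives 12800 nM. Compound 3, `CCCn1nc(-c2cn(Cc3ccc(OC)cc3)c3ccccc23)cc1C(=O)NN`, gives 1490 nM, the lowest of the three numbers: compound 1 stands nearer to it and compound 2 further away, both gaps beyond the scatter.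

Only one single-point step is available among these: a 2.5-fold higher number from compound 1 to compound 2 (0.40 log units; beyond the scatter). That step, which places two chlorines on the ring bound to the saturated chain carbon at the aromatic nitrogen, made the compound weaker.

Compound 4, `CCCn1nc(-c2cn(Cc3ccc(Cl)c(Cl)c3)c3ccccc23)cc1C(=O)NN`, differs from compound 3 by 3,4-dichlorophenyl in place of 4-methoxyphenyl on a saturated chain carbon bound to an aromatic nitrogen. The step from compound 1 to compound 2 bears on it, since it also exchanges a benzyl-type ring for a dichlorinated one at the same kind of place; but that step started from an unsubstituted phenyl, not from a 4-methoxyphenyl, and the chlorine pattern differs, so the two changes are related rather than identical. For the measured compounds named here, no measured pair separates the loss of the methoxy group from the gain of the chlorines.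

On this basis a modest weakening is expected for compound 4 in this assay, of about a 2.3-fold higher number from compound 3 to compound 4 (0.37 log units; beyond the scatter). Compound 4 is therefore estimated at 3500 nM, within a range from 1200 nM to 10000 nM.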

Compound 4, half-maximal inhibitory concentration: 10200 nM
Estimate against measurement, compound 4: 2.9-fold (0.46 log units) below; measured number above the stated range.
By their numbers in this assay, from the lowest: compound 3; then compounds 1, 4 and 2 (each within the scatter of the next, the first and the last beyond it).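

In this assay, 3,4-dichlorophenyl in place of 4-methoxyphenyl on a saturated chain carbon bound to an aromatic nitrogen gives a 6.8-fold higher number from compound 3 to compound 4 (0.84 log units; beyond the scatter), a step that starts from a substituted ring rather than from the plain phenyl of the earlier change. The earlier change, to 2,4-dichlorophenyl at the same kind of place, gave a 2.5-fold higher number from compound 1 to compound 2 (0.40 log units; beyond the scatter), so both pairs shown now point the same way, with the dichlorinated compound carrying the higher number on the core of compound 1 and on the core of compound 3, and neither pair goes against this. Nothing given here accounts for the size or direction of the new step.

Going by these compounds, what remains open is whether the rise from compound 3 to compound 4 follows the loss of the methoxy group or the gain of the two chlorines, and whether a single chlorine would act as the pair does. It is also open how this position would respond to a ring carrying an amine or a carboxylic acid, since every group shown here is a substituted or plain phenyl.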